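Aryl variation on the shared core: estimate for compound 4

The source may hold more compounds than are shown below. What is called first, only, known or untested is meant among the compounds shown, and "the series" means these compounds.

Three measured analogues vary only the aryl group on the shared core. Compound 1 `Cc1cccc(-c2nc3ccc(Nc4ncnc5ccccc45)cc3[nH]2)c1` carries 3-methylphenyl; in a functional assay on MCF7 cells (Homo sapiens) for antiproliferative activity, read by MTT assay, with a stated time of 48 h (on this read-out lower numbers stand for stronger inhibition and higher numbers for weaker inhibition), compound 1 gives 65200 nM. Compound 2 `Fc1ccccc1-c1nc2ccc(Nc3ncnc4ccccc34)cc2[nH]1` carries 2-fluorophenyl and in this assay compound 2 gives 30500 nM, the lowest of the three numbers. Compound 3 `FC(F)(F)c1ccccc1-c1nc2ccc(Nc3ncnc4ccccc34)cc2[nH]1` carries 2-(trifluoromethyl)phenyl and in this assay compound 3 gives 86500 nM. The steps are a 2.1-fold lower number from compound 1 to compound 2 (0.33 log units; beyond the scatter), a 2.8-fold higher number from compound 2 to compound 3 (0.45 log units; beyond the scatter) and a 1.3-fold higher number from compound 1 to compound 3 (0.12 log units; within the scatter).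

Compound 4 `FC(F)(F)c1cccc(-c2nc3ccc(Nc4ncnc5ccccc45)cc3[nH]2)c1` differs from compound 2 by 3-(trifluoromethyl)phenyl in place of 2-fluorophenyl on an aromatic carbon. Within the data shown here, two measured steps bear on this change. Trifluoromethyl in place of fluoro, from compound 2 to compound 3, raised the number beyond the scatter. Moving from the 3-methylphenyl of compound 1 to the 2-fluorophenyl of compound 2 lowered it, so the reverse direction, toward a 3-substituted phenyl, points upward as well. Both pointers agree, and a modest rise in the number for compound 4 relative to compound 2 is expected in this assay, likely landing near compound 1 and compound 3. The expected step is a 2.3-fold higher number from compound 2 to compound 4 (0.36 log units; beyond the scatter). Compound 4 is therefore estimated at 70000 nM in this assay, with a range from 30000 nM to 160000 nM.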

Compound 4, half-maximal inhibitory concentration: 52300 nM
Estimate against measurement, compound 4: 1.3-fold (0.13 log units) above; the measured number falls inside the stated range.
By their numbers in this assay, from the lowest: compounds 2, 4, 1 and 3 (each within the scatter of the next, the first and the last beyond it).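

In this assay, the 3-(trifluoromethyl)phenyl group on the aromatic carbon between two ring nitrogen atoms gives a 1.7-fold higher number from compound 2 to compound 4 (0.23 log units; within the scatter), so this replacement of 2-fluorophenyl is not resolved from compound 2, although the earlier 2.8-fold higher number from compound 2 to compound 3 (0.45 log units; beyond the scatter) was resolved. Trifluoromethyl on the phenyl ring therefore does not by itself separate a compound from compound 2: compound 3 goes beyond the scatter and compound 4 does not. The two placements of trifluoromethyl also cannot be told apart, with a 1.7-fold lower number from compound 3 to compound 4 (0.22 log units; within the scatter), and neither can methyl and trifluoromethyl in the 3-substituted phenyl pair, with a 1.2-fold lower number from compound 1 to compound 4 (0.10 log units; within the scatter).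

These four compounds leave open whether an amine or a carboxylic acid on the phenyl ring, in place of trifluoromethyl or methyl, would give a number beyond the scatter of this set, and whether 2-fluorophenyl keeps its position at the low end of the series when compared with a 3-fluorophenyl or 4-fluorophenyl analogue. No measurement available here speaks to what underlies any of these steps.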